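Glycine in place of the dimethylated aminoethyl side chain

The source may report more compounds than this note shows. Statements on the series, on what has been measured and on what is new or still open speak of the compounds shown alone.

The shared core of compound 1 `C[C@@H](N)C(=O)N[C@@H]1CCc2ccccc2N(Cc2ccc(-c3ccccc3-c3nn[nH]n3)cc2)C1=O` carries an amide at the lactam ring; in this series it is measured in a functional assay on cells (Pituitary gland cell) with growth hormone secretagogue receptor type 1 (Rattus norvegicus) as the target (a lower number here means that less compound is needed, a higher number that more compound is needed for the effect), where compound 1 gives 0.1 uM; 1.4 uM (2 entries), a spread documented in the several entries of compound 1 in this assay, 0.1 uM; 1.4 uM (2 entries). Going by the values given here, compound 2 `CC(C)(CN)C(=O)N[C@@H]1CCc2ccccc2N(Cc2ccc(-c3ccccc3-c3nn[nH]n3)cc2)C1=O` bears a 1-(aminomethyl)-1-methylethyl group on the carbonyl carbon, and in this assay compound 2 gives 3 uM, the only number recorded for it; a further entry reports no single number.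

Compound 3 `NCC(=O)N[C@@H]1CCc2ccccc2N(Cc2ccc(-c3ccccc3-c3nn[nH]n3)cc2)C1=O` is the simplest member: aminomethyl in place of 1-(aminomethyl)-1-methylethyl on a carbonyl carbon. Among the compounds with values here, no directly measured step of this kind is available in this assay. Compound 1, with a methyl rather than the larger branched chain, sits around the values above, so a short unbranched aminomethyl is expected to stay in the same region, perhaps a little weaker, with the step from compound 2 to compound 3 estimated at a 1.3-fold higher number from compound 2 to compound 3 (0.12 log units; within the scatter). Compound 3 is therefore expected to give about 4 uM, within 0.6 uM to 20 uM.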

Compound 3, concentration for half-maximal effect: 9 uM
Estimate against measurement, compound 3: 2.3-fold (0.35 log units) below, within the range that was stated.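

Going by these compounds alone, replacing 1-(aminomethyl)-1-methylethyl with aminomethyl on the carbonyl carbon gives the first step that can be read at this position: in this assay the change produces a 3.0-fold higher number from compound 2 to compound 3 (0.48 log units; beyond the scatter). The two groups have the same count of hydrogen-bond donors and acceptors and neither carries a net charge, so this step goes with the loss of carbon atoms while the amine stays, and that loss is not neutral in this assay. Compound 3, at 9 uM, also stands above both entries of compound 1, but those two entries lie far apart, so that comparison can be read only loosely: the several entries of compound 1 in this assay, 0.1 uM; 1.4 uM (2 entries)

The compounds shown leave open how far the amine itself matters at this position, which a hydroxymethyl group on the same carbonyl carbon would address. They also leave open whether the step follows the length of the chain or its branching, and an unbranched 2-aminoethyl group, a longer chain without the methyl groups, would help to separate the two.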